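The source may hold more compounds than are shown below. What is called first, only, known or untested is meant among the compounds shown, and "the series" means these compounds.

Measured to date in a functional assay on HL-60 cells (Homo sapiens) for inhibition, read by MTT assay, with a stated time of 48 h; a lower number here means a stronger inhibitor, a higher number a weaker inhibitor:

compound 1, `Brc1ccc2c(Br)c(Br)[nH]c2c1Br`: 38000 nM
compound 2, `Clc1c(Br)[nH]c2c(Br)c(Br)ccc12`: 78000 nM
compound 3, `Clc1[nH]c2c(Br)c(Br)ccc2c1Cl`: 61000 nM

Compound 3 holds the second highest of the three numbers in this assay. Its nearest neighbour is compound 2, whose number is higher by a margin within the scatter; compound 1 gives a lower number, also within the scatter. Both measured steps are halogen swaps on an aromatic carbon: a 2.1-fold higher number from compound 1 to compound 2 (0.31 log units; beyond the scatter), a modest step beyond the scatter, and a 1.3-fold lower number from compound 2 to compound 3 (0.11 log units; within the scatter), within the scatter. Neither moved the number far.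

Compound 4, `Clc1[nH]c2c(Br)c(I)ccc2c1Cl`, has not yet been measured. It differs from compound 3 by iodo in place of bromo on an aromatic carbon. Among the compounds with values here, the two halogen swaps above are the only steps that bear on this change, and they point in opposite directions, the larger of them only modest. On that basis no step beyond the scatter is expected in this assay, with no clear direction. Compound 4 is therefore estimated to give about 50000 nM, expected to lie within 22000 nM to 110000 nM. The step this estimate implies is a 1.2-fold lower number from compound 3 to compound 4 (0.09 log units; within the scatter).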

Compound 4, half-maximal inhibitory concentration: 49000 nM
Estimate against measurement, compound 4: 1.0-fold (0.01 log units) above; the measured number falls inside the stated range.
By their numbers in this assay, from the lowest: compounds 1, 4, 3 and 2 (each within the scatter of the next, the first and the last beyond it).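

In this assay, the change of bromo to iodo gives a 1.2-fold lower number from compound 3 to compound 4 (0.10 log units; within the scatter), the first step shown at this aromatic carbon of the six-membered ring, ortho to a bromo group and para to a fused ring. Within the data shown here, the earlier steps replaced bromo with chloro, so this is also the first look at iodo, and here the exchange leaves the number indistinguishable from that of its parent, with compound 4 at 49000 nM. This single pair shows that one halogen exchange at this carbon is tolerated without a measurable shift, but no measurement shown offers an explanation for the result, or for the lack of a larger step.

The compounds shown have only halogens at this position, so it remains open whether an amine, a carboxylic acid, a methoxy group or a plain hydrogen there would move the number beyond the scatter. Also open is whether iodo in place of bromo would behave the same way at the other halogen-bearing carbons of the shared core, since only this one position has been shown with iodo.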